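The source may hold more compounds than are shown below. What is called first, only, known or untested is meant among the compounds shown, and "the series" means these compounds.

Two compounds of this series have numbers in a functional assay on MCF7 cells (Homo sapiens) for cytotoxicity, read by sulforhodamine B assay, with a stated time of 48 h; on this read-out higher numbers stand for weaker inhibition and lower numbers for stronger inhibition. Compound 1 `COc1ccc(C2C(C#N)=C(N)Oc3nc(Nc4ccc(S(N)(=O)=O)cc4)sc32)cc1` gives 27500 nM in this assay. Compound 2 `COc1ccc(C2C(C#N)=C(/N=C/c3ccccc3)Oc3nc(Nc4ccc(S(N)(=O)=O)cc4)sc32)cc1` gives 33600 nM in this assay. For the measured compounds named here, the only measured step, a 1.2-fold higher number from compound 1 to compound 2 (0.09 log units; within the scatter), lies within the scatter. Compound 2 thus holds the higher of the two numbers, but its gap to compound 1 is within the scatter, so no order between the two can be read from this assay.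

Compound 3 `COc1ccc(C2C(C#N)=C(/N=C/c3ccccc3Cl)Oc3nc(Nc4ccc(S(N)(=O)=O)cc4)sc32)cc1` has not yet been measured in this assay. It differs from compound 2 by chloro in place of hydrogen on an aromatic carbon. Going by the values given here, no measured step touches a substituent on that ring. Among the compounds with values here, the one step that exists, a 1.2-fold higher number from compound 1 to compound 2 (0.09 log units; within the scatter), put the whole group carrying this ring in place of a single nitrogen atom, and even that larger change stayed within the scatter. With nothing pointing either way, the step expected for the chloro substitution is a 1.0-fold lower number from compound 2 to compound 3 (0.01 log units; within the scatter), that is, no movement beyond the scatter. The estimate for compound 3 in this assay is therefore 33000 nM, with an expected range from 12000 nM to 90000 nM.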

Compound 3, half-maximal inhibitory concentration: 10300 nM
For compound 3 the middle estimate is 3.2-fold (0.51 log units) above the measured one, outside the stated range (below it).
By their numbers in this assay, from the lowest: compound 3; then compounds 1 and 2 (each within the scatter of the next).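

In this assay, the ring that entered with compound 2 proves able to move the number: the change from phenyl to 2-chlorophenyl gives a 3.3-fold lower number from compound 2 to compound 3 (0.51 log units; beyond the scatter), a modest step but the first in this series beyond the scatter. The larger replacement of one nitrogen atom on the double-bonded ring carbon now also registers, with a 2.7-fold lower number from compound 1 to compound 3 (0.43 log units; beyond the scatter), whereas the same replacement without the chloro gave only a 1.2-fold higher number from compound 1 to compound 2 (0.09 log units; within the scatter), so among these three compounds a shift beyond the scatter appears only when the chloro is present. Nothing at hand bears on why this single chlorine atom has this effect.

With chloro as the only substituent shown on this ring, it remains open whether fluoro, bromo, methyl or methoxy at the same carbon would give a similar step, and whether chloro at another carbon of the ring would do the same. From the compounds shown here alone, it is also open whether the step would persist if the methoxy group on the other aromatic ring of the shared core were replaced by a hydroxy group.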